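The source may hold more compounds than are shown below. What is called first, only, known or untested is meant among the compounds shown, and "the series" means these compounds.

Compound 1, `Fc1ccc(Cn2ccc3nc(-c4ccccc4)nc-3c2)cc1`: in an ADME assay on MDBK cells (Bos taurus) for cytotoxicity (a lower number here means that less compound is tolerated, a higher number that more compound is tolerated), compound 1 gives > 100000 nM, which is a limit of the assay rather than a number.
Compound 2, `Clc1cccc(Cn2ccc3nc(-c4ccccc4)nc-3c2)c1`: in this assay compound 2 gives > 100000 nM, again a limit of the assay.
Compound 3, `Brc1cccc(Cn2ccc3nc(-c4ccccc4)nc-3c2)c1`: in this assay compound 3 gives 85000 nM.

Within the data shown here, compound 3 thus holds the only number in the set; the two other values sit at the limit of > 100000 nM in this assay, at which 2 of the 3 values shown sit. The step of an at least 1.1-fold lower number from compound 1 to compound 3 (0.07 log units; that floor lies within the scatter) and the step of an at least 1.1-fold lower number from compound 2 to compound 3 (0.07 log units; that floor lies within the scatter) are each no more than a floor that lies within the scatter, and the step that the two limits leave unreadable from compound 1 to compound 2 cannot be read because both of its ends are limits. The unmeasured compound 4, `CCn1ccc2nc(-c3ccccc3)nc-2c1`, differs from compound 3 by methyl in place of 3-bromophenyl on a saturated chain carbon bound to an aromatic nitrogen. Among the measured compounds shown here, none of the measured steps exchanges the aromatic group on that chain carbon for a methyl, so they bear on the change only indirectly, by showing that the three measured compounds all sit close to one level of tolerance. Compound 4 is therefore expected to remain near that level or to come out as a limit once more, a change of a 1.2-fold higher number from compound 3 to compound 4 (0.07 log units; within the scatter). The estimate for compound 4 in this assay is 100000 nM, with a range from 50000 nM to 200000 nM.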

Compound 4, half-maximal cytotoxic concentration: > 100000 nM
Compound 4 gave a limit, no number; the forecaster's own chance of this, stated with the estimate: 70%; the middle value sits exactly at the limit.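

Among these compounds, the saturated chain carbon bound to an aromatic nitrogen now carries a group with no ring for the first time in this set: methyl, a single carbon, in place of 3-bromophenyl, and in this assay compound 4 still gives a limit of the assay rather than a number. Among the compounds shown here, the one step that can be read, an at least 1.1-fold higher number from compound 3 to compound 4 (0.07 log units; that floor lies within the scatter), is only a floor, and the steps from compound 1 and from compound 2 to compound 4 cannot be read, as both of their ends are limits. Losing the aromatic ring at this place therefore brings no sign of lower tolerance, and the set gathers further at a single value: the limit of > 100000 nM in this assay, at which 3 of the 4 values shown sit.

As far as these compounds go, how far compound 1, compound 2 and compound 4 lie past that limit stays open, so the set cannot tell whether exchanging an aromatic group for methyl moves tolerance at all. Also open, from the compounds shown here alone, is how a longer chain, an amine or a carboxylic acid on that saturated chain carbon would read in this assay.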